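Working notes on the series: compound 2 to compound 3

A few compounds are considered here, and "the series" means these few. Any claim that something is new, unique, unknown or untested is made for them only; others in the source may bear on it.

Measured compounds:
compound 1 `CC1=C(/C=C/C(=O)/C=C/c2ccccc2F)C(C)(C)CCC1` gives 23600 nM in a functional assay on Hep cells (Homo sapiens) for cytotoxicity, read by sulforhodamine B assay, with a stated time of 48 h; a higher number here means a weaker inhibitor, a lower number a stronger inhibitor
compound 2 `CC1=C(/C=C/C(=O)/C=C/c2ccccc2C)C(C)(C)CCC1` gives 41000 nM in this assay

Going by the values given here, compound 2 holds the highest of the two numbers in this assay, but its only neighbour is compound 1, and the step of a 1.7-fold higher number from compound 1 to compound 2 (0.24 log units; within the scatter) stays within the scatter, so the two compounds cannot be ordered.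

Compound 3 `CC1=C(/C=C/C(=O)/C=C/c2cccnc2)C(C)(C)CCC1` carries the change (pyridin-3-yl in place of 2-methylphenyl on a double-bonded chain carbon bound to a double-bonded chain carbon). Among the compounds with values here, the one measured step, a 1.7-fold higher number from compound 1 to compound 2 (0.24 log units; within the scatter), touches only a substituent on the aromatic ring and was small; no measured pair exchanges the ring itself, so the data give no direct guide for this swap. Without a precedent pointing either way, the expectation rests on the small movement seen so far, and no shift beyond the scatter is expected.

Compound 3 is therefore estimated at 35000 nM in this assay, with a range from 12000 nM to 100000 nM. This estimate means the step of a 1.2-fold lower number from compound 2 to compound 3 (0.07 log units; within the scatter) is expected.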

Compound 3, half-maximal inhibitory concentration: 45600 nM
Compound 3: the middle estimate sits 1.3-fold (0.11 log units) below what was measured; measured number inside the range.
By their numbers in this assay, from the lowest: compounds 1, 2 and 3 (each within the scatter of the next).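

Compound 3 exchanges the aromatic ring itself rather than a substituent on it, and in this assay the exchange gives a 1.1-fold higher number from compound 2 to compound 3 (0.05 log units; within the scatter) and a 1.9-fold higher number from compound 1 to compound 3 (0.29 log units; within the scatter), so neither step separates the compounds. At this position, on a double-bonded chain carbon bound to a double-bonded chain carbon, replacing a carbon-only ring with pyridin-3-yl, which brings 1 hydrogen-bond acceptor where 2-methylphenyl and 2-fluorophenyl have none, leaves all three compounds unordered. No measured evidence accounts for this result.

The compounds shown leave open whether any group at this position can move the number beyond the scatter, for instance an aminomethyl or carboxylic acid group on the aromatic ring. They also leave open what a longer chain between the carbonyl and the aromatic ring, or a change in the shared core, would do.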